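The compounds below may be only part of what the source reports. "The series", "measured", "known", "first", "only" and "open" are said of these compounds alone.

Going by the values given here, compound 3, `Nc1cccc2c(-c3cccc(NC(=O)Nc4cc(C(F)(F)F)cc(C(F)(F)F)c4)c3)ccnc12`, has the highest number of the three compounds measured so far in a functional assay on M14 cells (Homo sapiens) for antiproliferative activity, read by sulforhodamine B assay, with a stated time of 48 h; on this read-out lower numbers stand for stronger inhibition and higher numbers for weaker inhibition: compound 3 gives 2100 nM. Compound 1, `COc1ccc(C(=O)Nc2cccc(-c3ccnc4c(NC(C)=O)cccc34)c2)cc1OC`, gives 690 nM in this assay, and compound 2, `CC(=O)Nc1cccc2c(-c3cccc(NC(=O)c4ccc5c(c4)OCCO5)c3)ccnc12`, gives 98 nM. The one measured step among these, a 7.0-fold lower number from compound 1 to compound 2 (0.85 log units; beyond the scatter), changes the amide-bearing ring and does not touch the amino group. Compound 4, `CC(=O)Nc1cccc2c(-c3cccc(NC(=O)Nc4cc(C(F)(F)F)cc(C(F)(F)F)c4)c3)ccnc12`, differs from compound 3 in one place: acetyl in place of hydrogen on a nitrogen on an aromatic ring. Among the compounds with values here, no measured pair shows this change on its own, since compound 1 and compound 2 both carry the acetamido group but also an amide in place of the urea of compound 3, so their values can only hint that the acetamido-bearing compounds sit at lower numbers. On that indirect hint the expected step is a 2.1-fold lower number from compound 3 to compound 4 (0.32 log units; beyond the scatter), a modest move toward a lower number in this assay. Compound 4 is therefore estimated at 1000 nM, with a range from 300 nM to 3500 nM.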

Compound 4, half-maximal inhibitory concentration: 14200 nM
Compound 4: middle estimate off by 14-fold (1.15 log units), on the low side; the whole stated range lies below it.
By their numbers in this assay, from the lowest: compound 2; then compound 1; then compound 3; then compound 4.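

Read directly in this assay, the change from amino to acetamido on this nitrogen gives a 6.8-fold higher number from compound 3 to compound 4 (0.83 log units; beyond the scatter), so with the urea in place, acetyl goes with weaker inhibition than hydrogen. The low numbers of compound 1 and compound 2, which both carry the acetamido group, therefore do not carry over to the urea compounds, and acetamido alone does not go with a low number in this series. Nothing available explains why the number rises with this change.

The compounds shown leave open whether amino to acetamido has the same direction and size when the amide of compound 1 or compound 2 stands in place of the urea. They also leave open whether a methyl group, a propanoyl chain or a methanesulfonyl group on this nitrogen would read like hydrogen or like acetyl.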